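The source may report more compounds than this note shows. Statements on the series, on what has been measured and on what is new or still open speak of the compounds shown alone.

Compound 1 `CCCCc1cn(C[C@H](O)[C@H]2OC(=O)C(OCc3ccccc3)=C2OCc2ccccc2)nn1` — 18100 nM
Compound 2 `CC(C)(C)OC(=O)N1CCN(C(=S)SCc2cn(C[C@H](O)[C@H]3OC(=O)C(OCc4ccccc4)=C3OCc3ccccc3)nn2)CC1` — > 100000 nM
Compound 3 `COc1ccccc1-c1cn(C/C=C2\OC(=O)C(OCc3ccccc3)=C2OCc2ccccc2)nn1` — > 100000 nM

Within the data shown here, in a functional assay on HeLa cells (Homo sapiens) for antiproliferative activity, read by MTT assay, with a stated time of 72 h (on this read-out higher numbers stand for weaker inhibition and lower numbers for stronger inhibition), compound 1 gives 18100 nM, the only number among the three measured compounds. Compound 2 reaches only a limit of this assay, reported as > 100000 nM. Compound 3 likewise reaches only a limit of this assay, reported as > 100000 nM. Among the measured compounds shown here, two of the three results sit at the limit of > 100000 nM in this assay, at which 2 of the 3 values shown sit, so compound 1 stands as the sole compound with a measured number, and no step between two measured numbers is available.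

Compound 4 `O=C1O[C@H]([C@@H](O)Cn2cc(-c3cc(F)cc(F)c3)nn2)C(OCc2ccccc2)=C1OCc1ccccc1` differs from compound 1 in one place: 3,5-difluorophenyl in place of butyl on an aromatic carbon. For the measured compounds named here, with no measured step to rest on, the size of the change cannot be read from the data. Compound 3 carries an aromatic group on the same ring and reaches only a limit, but it also differs elsewhere, so its value is not a guide. Compound 1 is itself weak in this assay, and compound 4 is expected to stay in the same region, with a 1.4-fold higher number from compound 1 to compound 4 (0.14 log units; within the scatter) within or near the scatter. The estimate for compound 4 is 25000 nM, with a range from 8000 nM to 80000 nM.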

Compound 4, half-maximal inhibitory concentration: 40800 nM
Estimate against measurement, compound 4: 1.6-fold (0.21 log units) below, and the stated range covers the measured number.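

In this assay, among these compounds, the exchange of butyl for 3,5-difluorophenyl gives a 2.3-fold higher number from compound 1 to compound 4 (0.35 log units; beyond the scatter), the first step between two measured numbers in this set. This aromatic carbon therefore accepts a six-membered aromatic ring in place of a flexible chain with only a modest weakening, and compound 1 and compound 4 both remain weak inhibitors. Compound 4 gives a measured number and does not join the compounds that reach a limit: the limit of > 100000 nM in this assay, at which 2 of the 4 values shown sit.

From the compounds shown here alone, what a plain phenyl would give on this carbon stays open, and with it whether the ring itself or its two fluorine atoms account for the step. Also open, going by these compounds, is how a longer chain or an amine at this position would compare with butyl, since one step defines no trend.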